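Changing the aryl ether from compound 3 to compound 4

This account rests on a few compounds, and the source may have more. Where it says the series, first, only, none or still open, it means among the compounds named here.

In a functional assay (aorta) with Oryctolagus cuniculus as the target (a higher number here means weaker binding, a lower number tighter binding), compound 3 `CC(C)(C)c1ccc(OCCCN2CCC(C(c3ccc(F)cc3)c3ccc(F)cc3)CC2)cc1` gives 1 nM. Compound 2 `Fc1ccc(C(c2ccc(F)cc2)C2CCN(CCCOc3ccc(Br)cc3)CC2)cc1` gives 1.59 nM, which is within the scatter of compound 3. Among the measured compounds shown here, compound 1 `COc1cc(OCCCN2CCC(C(c3ccc(F)cc3)c3ccc(F)cc3)CC2)ccc1C(C)=O` gives 3.16 nM, and only this number stands clearly apart from compound 3.

The change under consideration leads to compound 4 `COc1ccccc1OCCCN1CCC(C(c2ccc(F)cc2)c2ccc(F)cc2)CC1`: 2-methoxyphenyl in place of 4-(tert-butyl)phenyl on an oxygen on a saturated carbon. In words, this is 2-methoxyphenyl in place of 4-(tert-butyl)phenyl on an oxygen on a saturated carbon.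

Three measured steps alter the group at this place. The first is a 1.6-fold lower number from compound 2 to compound 3 (0.20 log units; within the scatter), and the second is a 2.0-fold lower number from compound 1 to compound 2 (0.30 log units; within the scatter). Both stay within the scatter. The third is a 3.2-fold lower number from compound 1 to compound 3 (0.50 log units; beyond the scatter), the largest of the three and still modest. For the measured compounds named here, no measured compound carries the 2-methoxyphenyl group, so there is no direct precedent for it. Going by the values given here, the nearest comparison is compound 1, the only measured compound with a methoxy group, at 3.16 nM.

A modest move towards a higher number in this assay is therefore expected, on the scale of the largest measured step. The expected step is a 2.5-fold higher number from compound 3 to compound 4 (0.40 log units; beyond the scatter). For compound 4, the estimated value is 2.5 nM, with an expected range of 0.8 nM to 8 nM.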

Compound 4, dissociation constant: 2.51 nM
For compound 4 the middle estimate is 1.0-fold (0.00 log units) below the measured one; measured number inside the range.
By their numbers in this assay, from the lowest: compounds 3, 2, 4 and 1 (each within the scatter of the next, the first and the last beyond it).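

In this assay, among the compounds shown here, the 2-methoxyphenyl group is accepted on this oxygen at a modest cost against 4-(tert-butyl)phenyl, with a 2.5-fold higher number from compound 3 to compound 4 (0.40 log units; beyond the scatter) as the only new step beyond the scatter. Against the other two groups it cannot be separated, with a 1.6-fold higher number from compound 2 to compound 4 (0.20 log units; within the scatter) and a 1.3-fold lower number from compound 1 to compound 4 (0.10 log units; within the scatter), both within the scatter. The place therefore takes a group of 8 heavy atoms with one hydrogen-bond acceptor as well as one of 10 heavy atoms with none, and all four compounds stay inside the span of a 3.2-fold lower number from compound 1 to compound 3 (0.50 log units; beyond the scatter).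

No measurement at hand accounts for the differences among these aryl groups. Every compound shown keeps an aryl group on this oxygen and the same chain, so it remains open how the number responds to unsubstituted phenyl, to an aryl group carrying an amine or a carboxylic acid, or to a longer chain at this place.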